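The source may hold more compounds than are shown below. What is called first, only, known or untested is meant among the compounds shown, and "the series" means these compounds.

Among the measured compounds shown here, compound 1 `O=C1OCc2cc(N(Cc3ccc(C4CCCCC4)cn3)C(=O)[C@H]3CCN3S(=O)(=O)c3c(F)c(F)c(F)c(F)c3F)ccc21` gives, in a functional assay on MDA-MB-231 cells (Homo sapiens) for antiproliferative activity, with a stated time of 72 h (a higher number here means that more compound is needed for the effect, a lower number that less compound is needed), a value of 900 nM, the lower of the two numbers measured so far. Compound 2 `O=C(NO)c1ccc(N(Cc2ccc(C3CCCC3)cc2)C(=O)[C@H]2CCN2S(=O)(=O)c2c(F)c(F)c(F)c(F)c2F)cc1` gives 3100 nM in this assay, a gap beyond the usual scatter. The unmeasured compound 3 `O=C([C@H]1CCN1S(=O)(=O)c1c(F)c(F)c(F)c(F)c1F)N(Cc1ccc(C2CCCCC2)cn1)c1ccc2c(=O)[nH]cnc2c1` differs from compound 1 in a single place: a group of 11 heavy atoms (8 carbon, 2 nitrogen, 1 oxygen; one six-membered aromatic ring of carbon only, one six-membered aromatic ring with 2 hetero atoms) in place of a group of 10 heavy atoms (8 carbon, 2 oxygen; one five-membered non-aromatic ring with 1 hetero atom, one six-membered aromatic ring of carbon only), on an amide-type nitrogen. For the measured compounds named here, no measured pair shows how such an exchange moves this assay, so only a modest step is expected, one that may stay within the scatter: a 1.2-fold higher number from compound 1 to compound 3 (0.09 log units; within the scatter). Compound 3 is therefore estimated at 1100 nM, with a likely range from 350 nM to 3500 nM.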

Compound 3, half-maximal effective concentration: 3300 nM
Beside the measured number, compound 3's estimate is 3.0-fold (0.48 log units) below it; measured number inside the range.
By their numbers in this assay, from the lowest: compound 1; then compounds 2 and 3 (each within the scatter of the next).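

Among the compounds shown here, compound 1 and compound 3 give the first reading of a change on this amide-type nitrogen: with a six-membered aromatic ring with 2 hetero atoms and a hydrogen-bond donor entering, this assay shows a 3.7-fold higher number from compound 1 to compound 3 (0.56 log units; beyond the scatter), so this exchange is not neutral. Nothing measured here explains the shift.

The two groups differ in both their rings and their hydrogen-bond donors, and the compounds shown do not separate these two differences. Going by these compounds, how a group carrying a carboxylic acid or an amine would behave in this place remains open.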